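This account rests on a few compounds, and the source may have more. Where it says the series, first, only, none or still open, it means among the compounds named here.

Measured in a functional assay on DU-145 cells (Homo sapiens) for antiproliferative activity, read by fluorescence and propidium iodide staining, with a stated time of 96 h; on this read-out lower numbers stand for stronger inhibition and higher numbers for weaker inhibition:
Compound 1 `CC(O)(COc1cc(C(F)(F)F)cc(C(F)(F)F)c1)C(=O)Nc1ccc([N+](=O)[O-])cc1C(F)(F)F`: 11600 nM
Compound 2 `CC(O)(CS(=O)(=O)c1cccc(C(F)(F)F)c1)C(=O)Nc1cc(C(F)(F)F)cc(C(F)(F)F)c1`: 11500 nM

The two values lie within the scatter of each other, so compound 2 stands level with compound 1. Compound 3 `CC(O)(CS(=O)(=O)c1cccc(OC(F)(F)F)c1)C(=O)Nc1cc(C(F)(F)F)cc(C(F)(F)F)c1` differs from compound 2 by trifluoromethoxy in place of trifluoromethyl on an aromatic carbon, meta to a large group (trifluoromethoxy in place of trifluoromethyl on an aromatic carbon). Within the data shown here, no measured pair shows this change, so the expectation rests on compound 2 at 11500 nM, with no step beyond the scatter foreseen. The expected change is a 1.2-fold lower number from compound 2 to compound 3 (0.06 log units; within the scatter). For compound 3 the estimated value is 10000 nM, with an expected range of 3500 nM to 25000 nM.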

Compound 3, half-maximal inhibitory concentration: 14100 nM
Compound 3: middle estimate off by 1.4-fold (0.15 log units), on the low side; the range from low to high includes it.
By their numbers in this assay, from the lowest: compounds 2, 1 and 3 (each within the scatter of the next).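

Among these compounds, on an aromatic carbon meta to a large group, this is the only reading of trifluoromethoxy in place of trifluoromethyl, and in this assay it gives a 1.2-fold higher number from compound 2 to compound 3 (0.09 log units; within the scatter), so the two compounds stand level. The oxygen and its one hydrogen-bond acceptor thus bring no step beyond the scatter at this position in this assay. No evidence on the cause of this result is available. From the compounds shown here alone, whether an amine, a carboxylic acid or a nitrile in the same place would give a different number remains open, as does whether this exchange would read the same on another core.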